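Working notes on the triazole-substituted series, compound 2 to compound 4

The source may report more compounds than this note shows. Statements on the series, on what has been measured and on what is new or still open speak of the compounds shown alone.

Going by the values given here, compound 2 `CCCCCCC#Cc1c(CCCCCC)oc2nc(=O)n(Cc3cn(Cc4ccccc4)nn3)cc12` has the lowest of the two numbers so far in a functional assay on CFPAC-1 cells (Homo sapiens) for antiproliferative activity, read by MTT assay, with a stated time of 72 h (on this read-out lower numbers stand for stronger inhibition and higher numbers for weaker inhibition), giving 27300 nM. Its nearest neighbour, compound 1 `CCCCCCc1cc2cn(Cc3cn(Cc4ccccc4)nn3)c(=O)nc2o1`, gives 67000 nM in this assay. Among the compounds with values here, the one measured step, a 2.5-fold lower number from compound 1 to compound 2 (0.39 log units; beyond the scatter), is the only change read so far. Within the data shown here, compound 3 `O=c1nc2oc(C3CC3)cc2cn1Cc1cn(-c2ccc(Cl)cc2)nn1` returns only a limit, > 100000 nM in this assay, and differs from compound 2 in more than one place, so no single step can be drawn from it; the limit is noted as the limit of > 100000 nM in this assay, at which 1 of the 3 values shown sits.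

Compound 4 `CCCCCCC#Cc1c(CCCCCC)oc2nc(=O)n(Cc3cn(-c4ccc(F)cc4)nn3)cc12` differs from compound 2 by 4-fluorophenyl in place of benzyl on an aromatic nitrogen. Among the measured compounds shown here, no measured step bears directly on this change: the step from compound 1 to compound 2 concerns a different position, and compound 3, the only compound that carries an aryl group rather than benzyl on the ring nitrogen, gives no number and is altered elsewhere as well. The expectation for this assay is therefore a step of about the scatter or a little beyond it, with the direction leaning toward a higher number given that compound 3 sits at the limit, that is a 1.5-fold higher number from compound 2 to compound 4 (0.17 log units; within the scatter). Compound 4 is estimated at 40000 nM in this assay, within 12000 nM to 100000 nM.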

Compound 4, half-maximal inhibitory concentration: > 100000 nM
Compound 4: no number, only a limit; the forecaster's own chance of this, stated with the estimate: 25%; at least 2.5-fold (0.39 log units) between middle value and limit.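

Going by these compounds alone, with the rest of compound 2 unchanged, 4-fluorophenyl in place of benzyl on an aromatic nitrogen of a five-membered aromatic ring with 3 nitrogen gives the first measured step at this position in this assay: an at least 3.6-fold higher number from compound 2 to compound 4 (0.56 log units; beyond the scatter). This step is beyond the scatter and marks only the smallest possible change, and it shows that the oct-1-yn-1-yl group, which accounts for a 2.5-fold lower number from compound 1 to compound 2 (0.39 log units; beyond the scatter), does not keep a measured number in this assay once benzyl is replaced. Compound 4 gives a limit and not a number, so the size of the loss stays unbounded on one side, and the top of the measurable range now holds compound 3 and compound 4: the limit of > 100000 nM in this assay, at which 2 of the 4 values shown sit.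

From the compounds shown here alone, what stays open is whether the change turns on the fluorine or on the loss of the carbon linking the ring to the nitrogen, a question that plain phenyl and 4-fluorobenzyl at this place would separate. Also open, going by these compounds, is how far this position tolerates other groups, such as a 2-phenylethyl chain or a benzyl carrying a carboxylic acid.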